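Demethylation of a Flavone Amide: Expected Inhibition

A few compounds are considered here, and "the series" means these few. Any claim that something is new, unique, unknown or untested is made for them only; others in the source may bear on it.

compound 1 `COc1cc2oc(-c3cccc(NC(=O)c4ccc(Br)cc4)c3)cc(=O)c2c(OC)c1OC` – 63.6%
compound 2 `COc1cc2oc(-c3cccc(C(=O)Nc4ccc(Cl)cc4)c3)cc(=O)c2c(OC)c1OC` – 129%

Among the measured compounds shown here, in a functional assay on RXF 393 cells (Homo sapiens) for inhibition, read by sulforhodamine B assay, tested at 10 uM (a lower number here means less inhibition, a higher number more inhibition at the concentration tested (going by the name of the read-out)), compound 2 gives the higher of the two numbers measured so far, and the step of a number 65.4 percentage points higher from compound 1 to compound 2 (beyond the scatter) sets it apart from compound 1. Compound 3 `COc1cc2oc(-c3cccc(C(=O)Nc4ccc(Cl)cc4)c3)cc(=O)c2c(O)c1OC` differs from compound 2 by hydrogen in place of methyl on an oxygen on an aromatic ring. For the measured compounds named here, no measured step touches this change; the single step seen alters the linkage and its halogen, not the oxygen substituent, so it does not bear on compound 3. The step of a number 19 percentage points lower from compound 2 to compound 3 (beyond the scatter) is therefore expected to lie within the scatter. For compound 3 the value is estimated at 110%, between 70% and 140%.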

Compound 3, a percentage reported as inhibition, at one concentration (the size of the read-out at that concentration, not a potency): 53%
Beside the measured number, compound 3's estimate is 57 percentage points above it, and the stated range ends above it.
By their numbers in this assay, from the lowest: compound 3; then compound 1; then compound 2.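

In this assay, replacing methoxy with hydroxy on this aromatic ring gives a number 76 percentage points lower from compound 2 to compound 3 (beyond the scatter), so this oxygen substituent strongly affects the read-out. The earlier compounds shown here all carried methoxy here and varied only the linkage and halogen, so they could not show this sensitivity. No available evidence explains the drop.

The compounds shown leave open whether an ethoxy group or an amine in this place would restore the number. They also leave open whether the other methoxy groups on the shared core respond in the same way.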